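A Halogen Swap on Compound 2

A few compounds are considered here, and "the series" means these few. Any claim that something is new, unique, unknown or untested is made for them only; others in the source may bear on it.

Of the compounds shown here, two sharing one core have so far been measured in an assay on isolated protein for inhibition of protein kinase C zeta type (Homo sapiens), with a stated time of 4 min, tested at 62.5 uM; a lower number here means less inhibition, a higher number more inhibition at the concentration tested (going by the name of the read-out). Compound 1 `CC(C)(C)C1=NN(c2ccc(F)c(F)c2F)C(c2ccc(O)cc2)C1` gives 91.7%. Compound 2 `CC(C)(C)C1=NN(c2ccc(Cl)cc2)C(c2ccc(F)cc2)C1` gives 0%, the lower of the two numbers, and the gap to compound 1 lies beyond the usual scatter. Compound 3 `CC(C)(C)C1=NN(c2ccc(Cl)cc2)C(c2ccc(Cl)cc2)C1` has not yet been measured; it differs from compound 2 by chloro in place of fluoro on an aromatic carbon. For the measured compounds named here, no single-change step between measured compounds is available, so in this assay only a small upward step is expected. Compound 3 is estimated at 10%, within 0% to 35%, an expected step of a number 10 percentage points higher from compound 2 to compound 3 (within the scatter).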

Compound 3, a percentage reported as inhibition, at one concentration (the size of the read-out at that concentration, not a potency): 11.8%
For compound 3 the middle estimate is 1.8 percentage points below the measured one; measured number inside the range.
By their numbers in this assay, from the lowest: compound 2; then compound 3; then compound 1.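

In this assay, for the compounds shown here, replacing the 4-fluorophenyl with 4-chlorophenyl gives the first single-change reading at this position, para to a large group: a number 11.8 percentage points higher from compound 2 to compound 3 (beyond the scatter). Exchanging one halogen for another here therefore has a modest effect, beyond the scatter, with no change in the count of hydrogen-bond donors or acceptors. Nothing available accounts for this step. 

On these data alone, it remains open whether an amine or a carboxylic acid at this position would shift the inhibition further. Also open, as far as these compounds go, is whether the same chloro-for-fluoro change would have a similar effect on the substitution pattern of compound 1.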